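The source may hold more compounds than are shown below. What is called first, only, known or untested is meant among the compounds shown, and "the series" means these compounds.

Of the compounds shown here, two of a shared core have been measured in a functional assay on HEK293 cells for agonist activity at Vasopressin V2 receptor (Homo sapiens), read by a luciferase reporter and cAMP accumulation; a higher number here means that more compound is needed for the effect, a lower number that less compound is needed. Compound 1 `CCc1cc(C(=O)N2CCCCc3ccccc32)ccc1CNC(=O)Nc1c(F)cccc1F` carries a urea closing onto a difluorophenyl group, and in this assay compound 1 gives 10 nM. Compound 2 `Cc1cc(C(=O)N2CCCCc3ccccc32)ccc1CNC(=O)NCC(=O)N1CCCC1` carries instead a urea that runs on into a pyrrolidinyl amide, and in this assay compound 2 gives 100 nM. Among the two numbers compound 2 stands highest, its nearest neighbour being compound 1 with a lower number, a gap that lies beyond the usual scatter.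

Compound 3 `CO[C@@H]1C[C@@H](C(=O)N(C)C)N(C(=O)NCc2ccc(C(=O)N3CCCCc4ccccc43)cc2C)C1` has not yet been measured. It differs from compound 2 in one place: 2-(dimethylcarbamoyl)-4-methoxypyrrolidin-1-yl in place of (((pyrrolidin-1-yl)carbonyl)methyl)amino on a carbonyl carbon. The urea is kept, but the open-chain arm of compound 2 is closed into a ring that loses the single hydrogen-bond donor and brings two defined stereocentres and two acceptors.

Within the data shown here, no comparable step is available to anchor a direction, so the expected step from compound 2 to compound 3, a 1.3-fold lower number from compound 2 to compound 3 (0.10 log units; within the scatter), is modest and could fall either way. For compound 3 in this assay an estimate of 80 nM is expected, within a range from 20 nM to 400 nM.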

Compound 3, half-maximal effective concentration: 4.7 nM
For compound 3 the middle estimate is 17-fold (1.23 log units) above the measured one, outside the stated range (below it).
By their numbers in this assay, from the lowest: compound 3; then compound 1; then compound 2.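

In this assay, among these compounds, the group on the urea carbonyl carbon turns out to weigh heavily: putting 2-(dimethylcarbamoyl)-4-methoxypyrrolidin-1-yl in place of (((pyrrolidin-1-yl)carbonyl)methyl)amino gives a 21-fold lower number from compound 2 to compound 3 (1.33 log units; beyond the scatter), a large step that the earlier compounds gave no sign of. The hydrogen-bond donor of the leaving group is also not required for a low number at this place, as the entering group has 0 hydrogen-bond donors and compound 3 still gives 4.7 nM in this assay. Nothing measured here accounts for the step.

The change alters several things at once, so the compounds shown leave open how much of the step belongs to the methoxy group, the dimethylcarbamoyl group or the 2 defined stereocentres. A plain pyrrolidin-1-yl on the same carbonyl carbon, a hydroxy group in place of the methoxy group, a carboxylic acid in place of the dimethylcarbamoyl group and the mirror-image arrangement of the stereocentres would each separate these contributions.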